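This account rests on a few compounds, and the source may have more. Where it says the series, first, only, none or still open, it means among the compounds named here.

Measured so far:
compound 1, `CCCCCCn1cnc2c(Nc3ccc(O)cc3)nc(N[C@H]3CC[C@H](N)CC3)nc21`, 190 nM
compound 2, `CCCCCCn1cnc2c(Nc3cccc(Cl)c3)nc(N[C@H]3CC[C@H](N)CC3)nc21`, 310 nM
compound 3, `CCCCn1cnc2c(Nc3cc(OC)cc(OC)c3)nc(N[C@H]3CC[C@H](N)CC3)nc21`, 370 nM

All three were tested in a functional assay on EOL1 cells (Homo sapiens) for inhibition, read by fluorescence, with a stated time of 72 h; on this read-out higher numbers stand for weaker inhibition of growth and lower numbers for stronger inhibition of growth. Compound 3 gives the highest of the three numbers, but its gap to compound 2 and its gap to compound 1 both lie within the scatter, so no order among the three can be read from these values. Among the compounds with values here, the only single-point step available, a 1.6-fold higher number from compound 1 to compound 2 (0.21 log units; within the scatter), concerns the group on the anilino nitrogen and is itself within the scatter.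

Compound 4, `CCCCCCn1cnc2c(Nc3cc(OC)cc(OC)c3)nc(N[C@H]3CC[C@H](N)CC3)nc21`, has not yet been measured. It differs from compound 3 by ethyl in place of hydrogen on a saturated chain carbon, four bonds along the chain from an aromatic nitrogen. Within the data shown here, no measured step changes the chain on the aromatic nitrogen while leaving the rest fixed, so nothing here speaks directly to the size or direction of this change. What the data do show is that compound 1 and compound 2, which already carry the longer chain, sit within the scatter of compound 3 in this assay.

On that basis the step of a 1.3-fold lower number from compound 3 to compound 4 (0.12 log units; within the scatter) is expected to stay within the scatter. Compound 4 is therefore estimated at 280 nM, with a likely range from 120 nM to 650 nM.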

Compound 4, concentration for 50% growth inhibition: 380 nM
Beside the measured number, compound 4's estimate is 1.4-fold (0.13 log units) below it, within the range that was stated.
By their numbers in this assay, from the lowest: compounds 1, 2, 3 and 4 (each within the scatter of the next).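

In this assay, ethyl in place of hydrogen on a saturated chain carbon, four bonds along the chain from an aromatic nitrogen, gives a 1.0-fold higher number from compound 3 to compound 4 (0.01 log units; within the scatter), so this first direct reading of the chain shows no difference that can be told from the scatter. With that chain held fixed, the group on the nitrogen on an aromatic ring can also be compared: 3,5-dimethoxyphenyl in place of 3-chlorophenyl gives a 1.2-fold higher number from compound 2 to compound 4 (0.09 log units; within the scatter), and 3,5-dimethoxyphenyl in place of 4-hydroxyphenyl gives a 2.0-fold higher number from compound 1 to compound 4 (0.30 log units; within the scatter), and both steps lie within the scatter. Neither place therefore separates these compounds in this read-out, and nothing measured alongside these numbers offers an explanation for them.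

The compounds shown leave open whether a methyl group or a much longer chain such as decyl on that aromatic nitrogen would move the number beyond the scatter. They also leave open what a carboxylic acid or a dimethylamino group on the phenyl ring would do, and what would follow if the amine shared by all four compounds were replaced by a hydroxyl group.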